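This account rests on a few compounds, and the source may have more. Where it says the series, first, only, none or still open, it means among the compounds named here.

Working notes on the series.

In an assay on IM-9 cells for displacement of a labelled ligand from Substance-P receptor (Homo sapiens), read by scintillation counting, with a stated time of 30 min (on this read-out higher numbers stand for weaker inhibition and lower numbers for stronger inhibition), compound 1 `CC(=O)N1CC[C@H](C(=O)N(C)Cc2cc(C(F)(F)F)cc(C(F)(F)F)c2)[C@H](c2ccccc2)C1` gives 3.2 nM. Compound 2 `CC(=O)NCC(=O)N1CC[C@@H](C(=O)N(C)Cc2cc(C(F)(F)F)cc(C(F)(F)F)c2)[C@H](c2ccccc2)C1` carries a longer acyl group on the ring nitrogen of the shared core and in this assay gives 12 nM. Compound 3 `CC(=O)N1CCC(C(=O)N2CC[C@H](C(=O)N(C)Cc3cc(C(F)(F)F)cc(C(F)(F)F)c3)[C@@H](c3cccc(C)c3)C2)CC1` combines the (1-acetylpiperidin-4-yl)carbonyl group with 3-methylphenyl on the saturated ring carbon and gives 0.14 nM; it stands lowest of the three numbers shown, with compound 1 the nearest to it and compound 2 the furthest, both beyond the scatter of this assay. Among the measured compounds shown here, no pair among the measured compounds differs in a single place, so no measured step can be set beside the change that follows.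

Compound 4 `CC(=O)N1CCC(C(=O)N2CC[C@H](C(=O)N(C)Cc3cc(C(F)(F)F)cc(C(F)(F)F)c3)[C@@H](c3ccccc3C(C)C)C2)CC1` has not been measured. It differs from compound 3 in one place: 2-isopropylphenyl in place of 3-methylphenyl on a saturated ring carbon. For the measured compounds named here, the series offers no measured example of a change at this position, so the expectation rests on compound 3 alone and on the distance of its value from the others. A moderate step toward a higher number, beyond the scatter but not back to the level of compound 1, is expected for a 4.3-fold higher number from compound 3 to compound 4 (0.63 log units; beyond the scatter). For compound 4 the estimate in this assay is 0.6 nM, with a range from 0.1 nM to 4 nM.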

Compound 4, half-maximal inhibitory concentration: 0.21 nM
Estimate against measurement, compound 4: 2.9-fold (0.46 log units) above; measured number inside the range.
By their numbers in this assay, from the lowest: compounds 3 and 4 (each within the scatter of the next); then compound 1; then compound 2.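

In this assay, among the compounds shown here, the exchange of 3-methylphenyl for 2-isopropylphenyl on the saturated ring carbon gives a 1.5-fold higher number from compound 3 to compound 4 (0.18 log units; within the scatter), the first measured step at this position, and it lies within the scatter, so compound 3 and compound 4 cannot be told apart on this read-out. With the (1-acetylpiperidin-4-yl)carbonyl group held constant, this position therefore accepts a change from the 7 heavy atoms of 3-methylphenyl to the 9 of 2-isopropylphenyl, with a different alkyl group at a different place on the phenyl ring, and the number stays at the level of compound 3. Nothing in hand explains why the two values stand so close.

Since the alkyl group and its place on the phenyl ring change together, this single step cannot separate the two, and a 3-isopropylphenyl or 2-methylphenyl group would be needed to do so. On these data alone, how far this tolerance extends also remains open, for instance to a phenyl ring bearing a carboxylic acid or an aminomethyl group, or to a pyridine ring in place of the phenyl ring.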